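A Butyl Swap at the Limit of the Assay

A few compounds are considered here, and "the series" means these few. Any claim that something is new, unique, unknown or untested is made for them only; others in the source may bear on it.

Compound 1 `C=CCNC(=C\C(=O)/C=C/c1ccc(O)c(OC)c1)/C=C/c1ccc(O)c(OC)c1` carries allyl on an amine nitrogen of the shared core, and compound 2 `COc1cc(/C=C/C(=O)/C=C(/C=C/c2ccc(O)c(OC)c2)NC2CCCCC2)ccc1O` carries cyclohexyl at that place. In a functional assay on HT-29 cells (Homo sapiens) for inhibition, read by MTT assay, with a stated time of 72 h (on this read-out higher numbers stand for weaker inhibition and lower numbers for stronger inhibition), compound 1 gives > 25000 nM, which is a limit of the assay and not a number. In this assay compound 2 gives > 25000 nM, which is likewise a limit and not a number. Compound 2 therefore has no measured number of its own and stands at the limit of > 25000 nM in this assay, at which 2 of the 2 values shown sit.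

Compound 3 `CCCCNC(=C\C(=O)/C=C/c1ccc(O)c(OC)c1)/C=C/c1ccc(O)c(OC)c1` is the next structure, and it differs from compound 2 as follows: butyl in place of cyclohexyl on an amine nitrogen. For the measured compounds named here, only one measured step bears on this change, a step that the two limits leave unreadable from compound 1 to compound 2, and it offers no size to carry over. Going by the values given here, no step of definite size or direction is therefore expected from the swap to butyl, and another limit is the likeliest result. The expected change in this assay is a step that the limit leaves unreadable from compound 2 to compound 3, with no direction supported by the data. The estimate for compound 3 is 28000 nM, with an expected range from 12000 nM to 60000 nM.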

Compound 3, half-maximal inhibitory concentration: 19700 nM
Compound 3: middle estimate off by 1.4-fold (0.15 log units), on the high side; low and high end bracket the measured number.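

Butyl on the amine nitrogen gives the only actual number among the compounds shown, so this position can yield a reading in this assay where allyl and cyclohexyl yielded none: the limit of > 25000 nM in this assay, at which 2 of the 3 values shown sit. The swap of cyclohexyl for butyl is recorded as an at least 1.2-fold lower number from compound 2 to compound 3 (0.10 log units; that floor lies within the scatter), and the comparison with the allyl compound is recorded as an at least 1.2-fold lower number from compound 1 to compound 3 (0.10 log units; that floor lies within the scatter). Both steps are floors set by limits, so their true size stays hidden, and neither floor alone shows a change beyond the usual scatter.

The compounds shown leave open whether the reading at this position follows chain length or the absence of a ring, a question that a shorter chain such as ethyl, a longer chain such as hexyl or a branched chain such as isobutyl on the amine nitrogen would bear on. They also leave open whether benzyl, or a chain ending in a hydroxyl group or a carboxylic acid, would give a number in this assay or another limit.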